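The compounds below may be only part of what the source reports. "The series", "measured", "known", "first", "only" and "open" are said of these compounds alone.

Measured in an ADME assay on HepG2 cells (Homo sapiens) for cytotoxicity, with a stated time of 72 h; on this read-out lower numbers stand for an effect already at smaller amounts and higher numbers for an effect only at larger amounts of compound (compound, structure, value):
compound 1 `Cc1cc(NC(=O)Nc2ccc(F)cc2)c2ccccc2n1` gives > 25000 nM (a limit)
compound 2 `Cc1cc(NC(=O)Nc2cccc(F)c2)c2ccccc2n1` gives > 25000 nM (a limit)
compound 3 `Cc1cc(NC(=O)Nc2ccc(SC(F)(F)F)cc2)c2ccccc2n1` gives 20000 nM

Compound 1 has no number, only (the limit of > 25000 nM in this assay, at which 2 of the 3 values shown sit).

Compound 4 `Cc1cc(NC(=O)Nc2ccc(F)cc2F)c2ccccc2n1` differs from compound 1 by fluoro in place of hydrogen on an aromatic carbon, ortho to a large group and meta to a fluoro group.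

Going by the values given here, two measured steps bear on this change. 3-fluorophenyl in place of 4-fluorophenyl gave a step that the two limits leave unreadable from compound 1 to compound 2, and (trifluoromethyl)sulfanyl in place of fluoro gave an at least 1.2-fold lower number from compound 1 to compound 3 (0.09 log units; that floor lies within the scatter). Neither shows a step beyond the scatter, so none is expected here.

The expected step is a number no higher from compound 1 to compound 4 (the limit leaves the size open), probably again reported only as a limit.

For compound 4 the estimate is 25000 nM, with an expected range of 15000 nM to 40000 nM.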

Compound 4, half-maximal effective concentration: 17000 nM
Beside the measured number, compound 4's estimate is 1.5-fold (0.17 log units) above it; the range from low to high includes it.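

In this assay, fluoro in place of hydrogen on an aromatic carbon, ortho to a large group and meta to a fluoro group, gives an at least 1.4-fold lower number from compound 1 to compound 4 (0.16 log units; that floor lies within the scatter). The earlier changes moved or replaced the existing group, whereas this one keeps it and adds a second group to the ring. The step has only a floor because compound 1 has no number, only a limit: the limit of > 25000 nM in this assay, at which 2 of the 4 values shown sit.

From the compounds shown here alone, whether a larger group at this position, such as an amine, a methoxy group or a carboxylic acid, would give a step beyond the scatter remains open.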